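Working notes on a ring-methyl step in the series

A few compounds are considered here, and "the series" means these few. Any claim that something is new, unique, unknown or untested is made for them only; others in the source may bear on it.

Compound 2 `NCC[C@@H]1CCO[C@H](c2ccccc2)O1` in an assay on brain for displacement of a labelled ligand from Sigma non-opioid intracellular receptor 1 (Cavia porcellus) (on this read-out lower numbers stand for stronger inhibition and higher numbers for weaker inhibition), gives > 10000 nM, which is a limit of the assay rather than a number. Compound 1 `C[C@@]1(c2ccccc2)OCC[C@@H](CCN)O1` in this assay likewise gives > 10000 nM, again a limit. The change between them, (methyl in place of hydrogen on a saturated ring carbon), therefore leaves a step that the two limits leave unreadable from compound 2 to compound 1; both values sit at the limit of > 10000 nM in this assay, at which 2 of the 3 values shown sit. Among the measured compounds shown here, compound 3 `c1ccc(CNCC[C@@H]2CCO[C@H](c3ccccc3)O2)cc1` in this assay gives 6 nM, the only number in the set; it differs from compound 2 by benzyl in place of hydrogen on an amine nitrogen, giving an at least 1600-fold lower number from compound 2 to compound 3 (3.22 log units; beyond the scatter). Compound 4 `C[C@@]1(c2ccccc2)OCC[C@@H](CCNCc2ccccc2)O1` carries the same kind of change as compound 1 against compound 2: methyl in place of hydrogen on a saturated ring carbon. The place differs in that the ring atom two ring bonds away here bears a large group, where in compound 1 it bears a 2-aminoethyl group. Because the same kind of change gave a step that the two limits leave unreadable from compound 2 to compound 1, compound 4 is expected to show a step of a 1.7-fold higher number from compound 3 to compound 4 (0.22 log units; within the scatter) and is estimated at 10 nM, between 2 nM and 50 nM.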

Compound 4, inhibition constant: 17 nM
Compound 4: middle estimate off by 1.7-fold (0.23 log units), on the low side, and the stated range covers the measured number.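

In this assay, methyl in place of hydrogen on the saturated ring carbon gives a readable step only on the core with the benzyl group, a 2.8-fold higher number from compound 3 to compound 4 (0.45 log units; beyond the scatter), while the same change on the core without it cannot be read, so this change has just one readable instance in the series. Benzyl in place of hydrogen on the amine nitrogen gives a large drop in the number on the methyl-bearing core too, an at least 580-fold lower number from compound 1 to compound 4 (2.76 log units; beyond the scatter). The direction of the benzyl change therefore carries from one core to the other, but its size cannot be compared: the same change on two cores in this assay, an at least 1600-fold lower number (3.22 log units; beyond the scatter) from compound 2 to compound 3 and an at least 580-fold lower number (2.76 log units; beyond the scatter) from compound 1 to compound 4; the limit leaves it open whether they differ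

From the compounds shown here alone, it remains open whether an ethyl group in place of the ring methyl would go the same way. Going by these compounds, it also remains open whether a phenethyl group on the amine nitrogen would keep the low numbers seen with benzyl.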